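The source may hold more compounds than are shown below. What is called first, only, known or untested is meant among the compounds shown, and "the series" means these compounds.

Measured so far:
compound 1 `CC(C)c1ccc(-n2cc(-c3cn([C@H]4C[C@H](O)[C@@H](CO)O4)c(=O)[nH]c3=O)nn2)cc1` — in an ADME assay on HEL cells (Homo sapiens) for cytotoxicity, read by cell counting, with a stated time of 3 days (a lower number here means that less compound is tolerated, a higher number that more compound is tolerated), compound 1 gives only a limit, > 240000 nM
compound 2 `O=c1[nH]c(=O)n([C@H]2C[C@H](O)[C@@H](CO)O2)cc1-c1cn(-c2ccc(Cl)cc2)nn1` — compound 2 likewise gives only a limit, > 240000 nM

Among the compounds with values here, compound 1 stands on no number in this assay, only at the limit of the measurement, and the one further value shown is a limit as well. Within the data shown here, the single measured step, a step that the two limits leave unreadable from compound 1 to compound 2, therefore says nothing about size or direction, because both of its ends rest at the limit of > 240000 nM in this assay, at which 2 of the 2 values shown sit.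

The next compound is compound 3 `O=c1[nH]c(=O)n([C@H]2C[C@H](O)[C@@H](CO)O2)cc1-c1cn(-c2ccc(Oc3ccccc3)cc2)nn1`. Relative to compound 1 the change is phenoxy in place of isopropyl on an aromatic carbon.

Among the measured compounds shown here, no measured step reads on this change. What is known is that compound 1 and compound 2, which differ at the same place, both tolerate compound up to the limit. The expectation for compound 3 in this assay is a step of a number no higher from compound 1 to compound 3 (the limit leaves the size open), that is, no change beyond the scatter. Compound 3 is thus estimated at 240000 nM, within 100000 nM to 500000 nM, most likely again reported as a limit.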

Compound 3, minimum cytotoxic concentration: 130000 nM
Beside the measured number, compound 3's estimate is 1.8-fold (0.27 log units) above it; the measured number falls inside the stated range.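

In this assay, compound 3 is the only compound shown that gives a number rather than a limit, so a phenoxy group at this position brings the reading inside the measurable range. Set against the isopropyl group, the change gives an at least 1.8-fold lower number from compound 1 to compound 3 (0.26 log units; that floor lies within the scatter), and set against the chloro group, it gives an at least 1.8-fold lower number from compound 2 to compound 3 (0.26 log units; that floor lies within the scatter). Both steps are floors without an upper end, because the other end of each is a limit: the limit of > 240000 nM in this assay, at which 2 of the 3 values shown sit.

With phenoxy as the only group of its kind shown, the ring and the oxygen cannot be separated as the source of the reading. On these data alone, how a methoxy group, a benzyl group, an amine or a carboxylic acid on this aromatic carbon would read in this assay remains open.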